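Carbamate and urea variants on a shared bis-amide core

The source may report more compounds than this note shows. Statements on the series, on what has been measured and on what is new or still open speak of the compounds shown alone.

Measured compounds:
- Compound 1 `CC(C)CC(=O)Nc1nc2ccc(NC(=O)c3c(Cl)cccc3Cl)cc2s1`: 0.012 ug/mL
- Compound 2 `CCOC(=O)Nc1nc2ccc(NC(=O)c3c(Cl)cccc3Cl)cc2s1`: 0.0026 ug/mL

Among the measured compounds shown here, in a functional assay on WI-38 VA13 cells (Homo sapiens) for cytotoxicity (on this read-out higher numbers stand for an effect only at larger amounts of compound and lower numbers for an effect already at smaller amounts), compound 2 gives the lower of the two numbers, and the single step that bears on the series, a 4.6-fold lower number from compound 1 to compound 2 (0.66 log units; beyond the scatter), lies beyond the scatter. Compound 3 `CC(C)NC(=O)Nc1nc2ccc(NC(=O)c3c(Cl)cccc3Cl)cc2s1` differs from compound 2 by isopropylamino in place of ethoxy on a carbonyl carbon. For the measured compounds named here, only that one step exists for comparison, and it concerns a different exchange at the same carbonyl carbon, so the direction for compound 3 is uncertain. Compound 3 is expected to land between the two measured values, estimated at 0.006 ug/mL with a range from 0.0015 ug/mL to 0.025 ug/mL, a step of a 2.3-fold higher number from compound 2 to compound 3 (0.36 log units; beyond the scatter).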

Compound 3, half-maximal effective concentration: 0.03 ug/mL
Estimate against measurement, compound 3: 5.0-fold (0.70 log units) below; the whole stated range lies below it.
By their numbers in this assay, from the lowest: compound 2; then compound 1; then compound 3.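

In this assay isopropylamino on the carbonyl carbon brings a 12-fold higher number from compound 2 to compound 3 (1.06 log units; beyond the scatter) and a 2.5-fold higher number from compound 1 to compound 3 (0.40 log units; beyond the scatter) and so gives the highest number of the three. Ethoxy, isobutyl and isopropylamino now stand apart beyond the scatter, so the group on this carbonyl carbon clearly shifts the read-out, with ethoxy lowest and isopropylamino highest in these compounds. Nothing at hand accounts for this order. As far as these compounds go, whether the shift follows the nitrogen or the branched chain stays open. Isopropoxy or ethylamino on the same carbonyl carbon would separate the two.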